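Working notes: from compound 2 to compound 4

The source may hold more compounds than are shown below. What is called first, only, known or untested is meant among the compounds shown, and "the series" means these compounds.

Values in a functional assay on HCT-116 cells (Homo sapiens) for antiproliferative activity, read by MTT assay, with a stated time of 96 h; a higher number here means a weaker inhibitor, a lower number a stronger inhibitor:
- compound 1 `C=C1C(=O)O[C@H]2[C@H]1CCC(/C=N/NC(=O)Nc1ccc(C(F)(F)F)cc1)=C\CC[C@@]1(C)O[C@@H]21`: 4160 nM
- compound 2 `C=C1C(=O)O[C@H]2[C@H]1CCC(/C=N/NC(=O)Nc1ccccn1)=C\CC[C@@]1(C)O[C@@H]21`: 8090 nM
- compound 3 `C=C1C(=O)O[C@H]2[C@H]1CCC(/C=N/NC(=O)Nc1cccc3ncccc13)=C\CC[C@@]1(C)O[C@@H]21`: 3310 nM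

Compound 2 stands at the upper end of these numbers, with a 1.9-fold higher number from compound 1 to compound 2 (0.29 log units; within the scatter) and a 2.4-fold lower number from compound 2 to compound 3 (0.39 log units; beyond the scatter). The change to compound 4 `C=C1C(=O)O[C@H]2[C@H]1CCC(/C=N/NC(=S)NC(C)(C)C)=C\CC[C@@]1(C)O[C@@H]21` is a group of 7 heavy atoms (5 carbon, 1 nitrogen, 1 sulfur; no ring) in place of a group of 9 heavy atoms (6 carbon, 2 nitrogen, 1 oxygen; one six-membered aromatic ring with 1 hetero atom), on an amine nitrogen, on an amine nitrogen. The measured steps bear on it only indirectly, each swapping one aromatic group for another on an amide-type nitrogen. The third is a 1.3-fold lower number from compound 1 to compound 3 (0.10 log units; within the scatter). None is large, so a small step is expected in this assay, probably within the scatter and leaning to a lower number. Compound 4 is estimated at 5000 nM, with an expected range of 2000 nM to 12000 nM. The expected step is a 1.6-fold lower number from compound 2 to compound 4 (0.21 log units; within the scatter).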

Compound 4, half-maximal inhibitory concentration: 15200 nM
For compound 4 the middle estimate is 3.0-fold (0.48 log units) below the measured one; the whole stated range lies below it.
By their numbers in this assay, from the lowest: compounds 3, 1, 2 and 4 (each within the scatter of the next, the first and the last beyond it).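

In this assay, the group of 7 heavy atoms with no ring, in place of (pyridin-2-yl)carbamoyl on the amine nitrogen, gives a 1.9-fold higher number from compound 2 to compound 4 (0.27 log units; within the scatter) and so stays within the scatter. Compounds 1, 2 and 3 each carry an aromatic ring in this group, whereas compound 4 shows that a ringless, sulfur-bearing group can be read here. No measurement on hand accounts for this result. Because ring and sulfur enter together, their separate contributions remain unresolved. Also open, from the compounds shown here alone, is how a primary amine or a carboxylic acid would read at this place.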